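Sulfur substituents on the shared core, antiproliferative read-out

A few compounds are considered here, and "the series" means these few. Any claim that something is new, unique, unknown or untested is made for them only; others in the source may bear on it.

Measured compounds and values:
Compound 1 `CSc1nnc(COc2cc(C)c3c(C)cc(=O)oc3c2)o1` — in a functional assay on MDA-MB-231 cells (Homo sapiens) for antiproliferative activity, read by MTT assay, with a stated time of 24 h (on this read-out higher numbers stand for weaker inhibition and lower numbers for stronger inhibition), compound 1 gives > 100000 nM, a limit of the assay.
Compound 2 `CCCCCCSc1nnc(COc2cc(C)c3c(C)cc(=O)oc3c2)o1` — in this assay compound 2 gives > 100000 nM, again a limit.
Compound 3 `Cc1cc(OCc2nnc(SCc3cccc(F)c3)o2)cc2oc(=O)cc(C)c12` — in this assay compound 3 gives > 100000 nM, likewise a limit.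

Compound 3 therefore stands at the limit of > 100000 nM in this assay, at which 3 of the 3 values shown sit; none of the three measured compounds has given a number in this assay, so no ordering among them can be read.

The next compound, compound 4 `CCS(=O)(=O)c1nnc(COc2cc(C)c3c(C)cc(=O)oc3c2)o1`, departs from compound 3 by ethylsulfonyl in place of (3-fluorobenzyl)sulfanyl on an aromatic carbon. The measured steps that touch the same position are a step that the two limits leave unreadable from compound 2 to compound 3 and a step that the two limits leave unreadable from compound 1 to compound 3, and the remaining step, a step that the two limits leave unreadable from compound 1 to compound 2, is equally unreadable. Three substituents of quite different size on the sulfur have all left the read-out at the limit, so the change to the ethylsulfonyl group in compound 4 gives no reason to expect a readable step in this assay in either direction.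

Compound 4 is accordingly expected to sit at or near the limit, with an estimate of 100000 nM spanning 30000 nM to 300000 nM. The expected step is a number no higher from compound 3 to compound 4 (the limit leaves the size open), which is not beyond the scatter.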

Compound 4, half-maximal inhibitory concentration: > 100000 nM
Compound 4: only a limit was reported; the forecaster's own chance of this, stated with the estimate: 85%; the middle value sits exactly at the limit.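

In this assay compound 4 gives > 100000 nM, a limit of the assay. Its steps from compound 1, compound 2 and compound 3 cannot be read, with all four compounds at the same limit: the limit of > 100000 nM in this assay, at which 4 of the 4 values shown sit.

The compounds shown leave open whether any substituent on the sulfur of the shared core gives a number in this assay, and how such substituents would rank.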